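Methyl for chloro on the pyridine-type ring of compound 1

This account rests on a few compounds, and the source may have more. Where it says the series, first, only, none or still open, it means among the compounds named here.

Measured compounds: compound 1 `Cc1ccccc1C(=O)Nc1cc(Cl)ccn1`, 128 uL/min; compound 2 `Cc1c(F)cccc1C(=O)Nc1cc(Cl)ccn1`, 254 uL/min; compound 3 `Cc1c(F)cccc1C(=O)Nc1ccccn1`, 58 uL/min.

In an ADME assay (liver) for metabolic stability, with Liver microsome (Homo sapiens) as the target, read by LC-MS, using microsomes, with a stated time of 60 min, tested at 1 uM (a higher number here means faster removal of the compound, a lower number slower removal), compound 1 gives 128 uL/min, the second highest of the three numbers; compound 2 lies nearest, with a 2.0-fold higher number from compound 1 to compound 2 (0.30 log units; within the scatter), while the number for compound 3 is lower and beyond the scatter. Compound 4 `Cc1ccnc(NC(=O)c2ccccc2C)c1` differs from compound 1 by methyl in place of chloro on an aromatic carbon. Within the data shown here, the only measured step at that position is a 4.4-fold lower number from compound 2 to compound 3 (0.64 log units; beyond the scatter), a modest step in this assay. A methyl is not a hydrogen, so that step is only a loose guide, and a small lower step or none beyond the scatter is expected. Compound 4 is therefore expected to give 90 uL/min, in the range 40 uL/min to 200 uL/min. The expected step is a 1.4-fold lower number from compound 1 to compound 4 (0.15 log units; within the scatter).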

Compound 4, intrinsic clearance in a liver preparation (reported as CLH), per the amount of preparation that the assay uses: 129 uL/min
For compound 4 the middle estimate is 1.4-fold (0.16 log units) below the measured one, and the stated range covers the measured number.
By their numbers in this assay, from the lowest: compound 3; then compounds 1, 4 and 2 (each within the scatter of the next).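

In this assay, methyl in place of chloro opposite the ring nitrogen gives a 1.0-fold higher number from compound 1 to compound 4 (0.00 log units; within the scatter) and so, unlike hydrogen in place of chloro in the fluoro-bearing pair, moves the number by nothing beyond the scatter. On the core of compound 1, then, a group at this position can change from chloro to methyl without a readable shift. Nothing shown here bears on why these two groups read alike.

As far as these compounds go, whether hydrogen at this position would lower the number without the fluoro remains open. So does how a methoxy, a nitrile or an amine there would read.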